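The source may report more compounds than this note shows. Statements on the series, on what has been measured and on what is new or still open speak of the compounds shown alone.

Three compounds built around one shared core have been examined in a functional assay on HEK293 cells for agonist activity at 5-hydroxytryptamine receptor 7 (Homo sapiens), read by a luciferase reporter and beta-arrestin recruitment, with a stated time of 22 h; a higher number here means a larger maximal response, a lower number a smaller maximal response. Compound 1 `CCCN(CCC)Cc1ccc(Cl)c(-c2ccccc2OC)c1` was reported in this assay as "not active" (no number reported), so no figure is available for it. Compound 2 `COc1ccccc1-c1cc(C2CCNC2)ccc1Cl` differs more widely from the other two, and in this assay compound 2 reached 54%. Compound 3 `CCNCc1ccc(Cl)c(-c2ccccc2OC)c1` was likewise reported in this assay as "not active" (no number reported), again without a number. Compound 3 therefore stands without a single value, sharing that position with compound 1, while compound 2 is the only one of the three with a measured maximal response.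

Compound 4 `CCCCNCc1ccc(Cl)c(-c2ccccc2OC)c1` is the next compound. Compared with compound 3, it shows (ethyl in place of hydrogen on a saturated chain carbon, two bonds along the chain from an amine nitrogen). Going by the values given here, no measured pair describes this kind of change, so the size of any step can only be guessed. Both compound 1 and compound 3 gave no measurable response, and compound 4 is an open-chain amine like them, so the expectation is a small or absent response rather than one approaching compound 2. For compound 4 in this assay the estimated maximal response is 15%, within a range of 0% to 45%, with a fair chance that only "not active" is reported again.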

Compound 4, largest response reached (Emax), in percent of the reference or control that the assay uses: "not active" (no number reported)
No number was reported for compound 4, so the estimate cannot be set against anything.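

Compound 3 and compound 4 are both reported without a number in this assay, so no step can be read between them. The compounds shown leave open whether any open-chain amine on the shared core gives a measurable response, as compound 2 does with 54%. No supporting data bear on this result.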